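The compounds below may be only part of what the source reports. "The series", "measured", "known", "first", "only" and "open" are said of these compounds alone.

In a functional assay on PC-3 cells (Homo sapiens) for cytotoxicity, read by MTT assay, with a stated time of 72 h (on this read-out lower numbers stand for stronger inhibition and higher numbers for weaker inhibition), compound 3 `CCc1ccc(-c2cc(C(=O)Nc3ccc(Oc4ccnc(C(=O)NC)c4)c(F)c3)ncn2)cc1` gives 15600 nM, which is within the scatter of compound 1 `CCc1ccc(-c2cc(C(=O)Nc3ccc(Oc4ccnc(C(=O)NC)c4)cc3)ncn2)cc1` at 29300 nM. Compound 2 `CNC(=O)c1cc(Oc2ccc(NC(=O)c3nccc(-c4ccc([N+](=O)[O-])cc4)n3)cc2)ccn1` yields only a limit of the assay, > 100000 nM. The next compound to be tested, compound 4 `CNC(=O)c1cc(Oc2ccc(NC(=O)c3cc(-c4ccccc4)ncn3)cc2F)ccn1`, keeps the core of compound 3 but has hydrogen in place of ethyl on an aromatic carbon, para to a large group, so that 4-ethylphenyl becomes phenyl (hydrogen in place of ethyl on an aromatic carbon). For the measured compounds named here, only one measured step links two compounds that differ in a single place: a 1.9-fold lower number from compound 1 to compound 3 (0.27 log units; within the scatter). This step is fluoro in place of hydrogen on an aromatic carbon, so it does not touch the ethyl and gives no direct measure of the coming change. Going by the values given here, with no measured step for this change, only a small shift in this assay is expected, leaning tentatively toward a higher number and not clearly beyond the scatter. The expected step is a 1.6-fold higher number from compound 3 to compound 4 (0.20 log units; within the scatter). For compound 4 the estimate is 25000 nM, with an expected range from 9000 nM to 70000 nM.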

Compound 4, half-maximal inhibitory concentration: 44300 nM
Estimate against measurement, compound 4: 1.8-fold (0.25 log units) below, and the stated range covers the measured number.
By their numbers in this assay, from the lowest: compounds 3, 1 and 4 (each within the scatter of the next, the first and the last beyond it). At a limit, above all of these: compound 2.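

In this assay, the ethyl group turns out to matter: a 2.8-fold higher number from compound 3 to compound 4 (0.45 log units; beyond the scatter). The only earlier step, a 1.9-fold lower number from compound 1 to compound 3 (0.27 log units; within the scatter), concerned a fluoro in place of hydrogen, so this is the first change among these compounds that moves the number beyond the scatter, and it does so at the aromatic carbon para to a large group. The data shown give no cause for this step.

As far as these compounds go, a single step shows only that ethyl and hydrogen differ at this place, so whether a longer chain, a methoxy group, an amine or a carboxylic acid there would move the number further stays open. Also open, from the compounds shown here alone, is whether the same change would give a similar step on the core of compound 1, which lacks the fluoro.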